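The source may hold more compounds than are shown below. What is called first, only, known or untested is meant among the compounds shown, and "the series" means these compounds.

Compound 1 `CCCCCCCCN(C)C(=O)Cn1cc(Cc2cnc(O)nc2)c(=O)nc1SCc1ccc(F)cc1` gives 34% in a functional assay on a cell-free system (plasma, Oryctolagus cuniculus) for inhibition of platelet-activating factor acetylhydrolase (Homo sapiens), tested at 100 nM; a lower number here means less inhibition, a higher number more inhibition at the concentration tested (going by the name of the read-out).
Compound 2 `CCCCCCCCN(C)C(=O)Cn1cc(Cc2cnc(=O)n(C)c2)c(=O)nc1SCc1ccc(F)cc1` gives 19% in this assay.
Compound 3 `CCCCCCCCN(C)C(=O)Cn1cc(Cc2cnc(=O)n(CC(=O)O)c2)c(=O)nc1SCc1ccc(F)cc1` gives 27% in this assay.

Among the three numbers, compound 3 stands second highest; its value and that of compound 1 lie within the scatter of each other, and so do its value and that of compound 2. Compound 4 `CCCCCCCCN(C)C(=O)Cn1cc(Cc2cnc(=O)n(CCO)c2)c(=O)nc1SCc1ccc(F)cc1` has not yet been measured. It differs from compound 3 in one place: hydroxymethyl in place of carboxy on a saturated chain carbon bound to an aromatic nitrogen. Among the measured compounds shown here, the one measured step that touches this position is a number 8 percentage points higher from compound 2 to compound 3 (within the scatter), in which carboxy took the place of hydrogen on a saturated chain carbon bound to an aromatic nitrogen. The other steps, a number 15 percentage points lower from compound 1 to compound 2 (beyond the scatter) and a number 7 percentage points lower from compound 1 to compound 3 (within the scatter), exchange the whole ring and bear on the change only indirectly. Because a number 8 percentage points higher from compound 2 to compound 3 (within the scatter) stayed within the scatter, the exchange of carboxy for hydroxymethyl is expected to stay within it as well, with an expected step of a number 3 percentage points lower from compound 3 to compound 4 (within the scatter). Compound 4 is therefore estimated at 24%, with a range from 12% to 36%.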

Compound 4, a percentage reported as inhibition, at one concentration (the size of the read-out at that concentration, not a potency): 36%
For compound 4 the middle estimate is 12 percentage points below the measured one; measured number inside the range.
By their numbers in this assay, from the lowest: compounds 2, 3, 1 and 4 (each within the scatter of the next, the first and the last beyond it).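

In this assay the step of a number 17 percentage points higher from compound 2 to compound 4 (beyond the scatter) shows that replacing hydrogen with hydroxymethyl on this saturated chain carbon bound to an aromatic nitrogen can move the read-out beyond the scatter, which the earlier step with carboxy in that place, a number 8 percentage points higher from compound 2 to compound 3 (within the scatter), did not show. The direct exchange, a number 9 percentage points higher from compound 3 to compound 4 (within the scatter), does not separate 2-hydroxyethyl from carboxymethyl. The step of a number 2 percentage points higher from compound 1 to compound 4 (within the scatter) likewise leaves compound 4 indistinguishable from compound 1 in this assay.

The compounds shown leave open whether an amine or a longer chain in this place would carry the read-out further than 2-hydroxyethyl does. They offer no measurement that could explain these steps.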